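This account rests on a few compounds, and the source may have more. Where it says the series, first, only, none or still open, it means among the compounds named here.

Compound 3 `C[C@H]1[C@H](NC(=O)OCCCCC2CCCCC2)C(=O)N1Oc1ccc(C(F)(F)F)cc1` gives 31 nM in an assay on HEK293 cells for inhibition of N-acylethanolamine-hydrolyzing acid amidase (Homo sapiens), read by fluorescence, with stated times of 10 min and 50 min (a higher number here means a weaker inhibitor, a lower number a stronger inhibitor), the lowest of the three numbers in hand, while compound 1 `C[C@H]1[C@H](NC(=O)OCCCCC2CCCCC2)C(=O)N1OCCCS(C)(=O)=O` gives 49 nM and compound 2 `CC(=O)CCCON1C(=O)[C@@H](NC(=O)OCCCCC2CCCCC2)[C@@H]1C` gives 75 nM. The step of a 1.6-fold lower number from compound 1 to compound 3 (0.20 log units; within the scatter) lies within the scatter, whereas a 2.4-fold lower number from compound 2 to compound 3 (0.38 log units; beyond the scatter) is modest but beyond it. Compound 4 `C[C@H]1[C@H](NC(=O)OCCCCC2CCCCC2)C(=O)N1Oc1ccc(Oc2ccccc2)cc1` differs from compound 3 by phenoxy in place of trifluoromethyl on an aromatic carbon. Among the measured compounds shown here, none of the measured steps alters a group on the aromatic ring; they exchange the whole group on the oxygen, and even there the number moved only by a 1.5-fold higher number from compound 1 to compound 2 (0.18 log units; within the scatter). The step of a 1.0-fold lower number from compound 3 to compound 4 (0.01 log units; within the scatter) is therefore expected to stay close to the scatter, with no clear direction. Compound 4 is estimated at 30 nM, within a range from 10 nM to 90 nM.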

Compound 4, half-maximal inhibitory concentration: 48 nM
The estimate for compound 4 lay 1.6-fold (0.20 log units) below the measured number; the measured number falls inside the stated range.
By their numbers in this assay, from the lowest: compounds 3, 4, 1 and 2 (each within the scatter of the next, the first and the last beyond it).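

Among the compounds shown here, this is the first change on the aromatic ring itself: in this assay, phenoxy in place of trifluoromethyl, para to a large group, gives a 1.5-fold higher number from compound 3 to compound 4 (0.19 log units; within the scatter). Phenoxy brings 7 heavy atoms and a six-membered aromatic ring where trifluoromethyl has 4 heavy atoms and no ring, yet the step stays within the scatter. No measurement in hand bears on what lies behind this result. From the compounds shown here alone, whether an amine or a carboxylic acid on this carbon would also stay within the scatter remains open.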